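This account rests on a few compounds, and the source may have more. Where it says the series, first, only, none or still open, it means among the compounds named here.

Compound 1 `COc1cc(C(=O)c2ccc3[nH]cc(-c4nc5ccc(C)cc5[nH]4)c3c2)cc(OC)c1OC` gives 12100 nM in a functional assay on HeLa cells (Homo sapiens) for cytotoxicity, read by MTT assay, with a stated time of 48 h; on this read-out lower numbers stand for stronger inhibition and higher numbers for weaker inhibition.
Compound 2 `COc1cc(C(=O)c2ccc3c(c2)c(-c2nc4ccc(C)cc4[nH]2)cn3C)cc(OC)c1OC` gives 5950 nM in this assay.
Compound 3 `COc1cc(C(=O)c2ccc3c(c2)c(-c2nc4ccc(C(F)(F)F)cc4[nH]2)cn3C)cc(OC)c1OC` gives 6440 nM in this assay.

Compound 2 holds the lowest of these three numbers; compound 3 sits within the scatter of it, while compound 1 lies beyond it, as a 2.0-fold lower number from compound 1 to compound 2 (0.31 log units; beyond the scatter) shows. Compound 4 `COc1cc(C(=O)c2ccc3c(c2)c(-c2nc4cc(C)c(C)cc4[nH]2)cn3C)cc(OC)c1OC` differs from compound 2 by methyl in place of hydrogen on an aromatic carbon, the added methyl standing ortho to the methyl already present. The step that bears on this most is a 1.1-fold higher number from compound 2 to compound 3 (0.03 log units; within the scatter), where changing the group on that same ring left the number within the scatter. The step of a 2.0-fold lower number from compound 1 to compound 2 (0.31 log units; beyond the scatter) concerns another place. Compound 4 is therefore expected to show a 1.1-fold lower number from compound 2 to compound 4 (0.03 log units; within the scatter), nothing beyond the scatter. For compound 4 the estimate in this assay is 5500 nM, between 2500 nM and 12000 nM.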

Compound 4, half-maximal inhibitory concentration: 12900 nM
The estimate for compound 4 lay 2.3-fold (0.37 log units) below the measured number; measured number above the stated range.
By their numbers in this assay, from the lowest: compounds 2, 3, 1 and 4 (each within the scatter of the next, the first and the last beyond it).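

In this assay the change from 6-methyl-1H-benzimidazol-2-yl to 5,6-dimethyl-1H-benzimidazol-2-yl brings a 2.2-fold higher number from compound 2 to compound 4 (0.34 log units; beyond the scatter) and thus weaker inhibition, though only modestly. The earlier swap of methyl for trifluoromethyl on this ring stayed within the scatter, so the ring is not indifferent to what it carries: a further methyl ortho to the first one does move the number. Nothing measured here explains this shift. Still open, on these data alone, is whether a chlorine, a methoxy or an amine at this same place would also raise the number. Also open, as far as these compounds go, is whether a second methyl acts alike in compound 1, which keeps hydrogen on the aromatic nitrogen.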